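A few compounds are considered here, and "the series" means these few. Any claim that something is new, unique, unknown or untested is made for them only; others in the source may bear on it.

Compound 1, `Nc1ncnc2c1ncn2[C@@H]1O[C@@H](CO)C=C1F`, was tested in a functional assay on Vero cells (Chlorocebus sabaeus) for inhibition; a lower number here means a stronger inhibitor, a higher number a weaker inhibitor. In this assay compound 1 gives only a limit, > 100000 nM, and not a number. The two other compounds in the set behave the same way. Compound 2, `Nc1nc(Cl)c2ncn([C@H]3O[C@@H](CO)C=C3F)c2n1`, in this assay gives the limit > 100000 nM. Compound 3, `Nc1ccn([C@H]2O[C@@H](CO)C=C2F)c(=O)n1`, in this assay likewise gives the limit > 100000 nM. Within the data shown here, compound 1 therefore stands where every value in the set stands, at the limit of > 100000 nM in this assay, at which 3 of the 3 values shown sit, and since no two measured compounds differ in just one place, no measured step exists to build on.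

The compound still to be measured is compound 4, `Nc1nc(F)nc2c1ncn2[C@@H]1O[C@@H](CO)C=C1F`. It differs from compound 1 by fluoro in place of hydrogen on an aromatic carbon.

Among the measured compounds shown here, because all three measured values sit at the limit of > 100000 nM in this assay, at which 3 of the 3 values shown sit, there is no reference step whose size could guide an expectation. The step that the limit leaves unreadable from compound 1 to compound 4 is expected to be none beyond the scatter, with the most likely outcome that this assay again reports a limit rather than a number. For compound 4 in this assay the expected half-maximal inhibitory concentration is 150000 nM, with a range from 30000 nM to 600000 nM.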

Compound 4, half-maximal inhibitory concentration: > 100000 nM
Compound 4 gave a limit, no number (the forecaster's own chance of this, stated with the estimate: 80%); the middle value does not contradict the limit.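

Compound 1 and compound 4 both give only a limit in this assay, so the size of the change from hydrogen to fluoro cannot be read from this pair: the limit of > 100000 nM in this assay, at which 4 of the 4 values shown sit.

The compounds shown leave open how strongly any of them inhibits, and whether any change to the shared core would give a number rather than a limit.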